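The source may hold more compounds than are shown below. What is called first, only, known or untested is meant among the compounds shown, and "the series" means these compounds.

Compound 1 `N#Cc1c(N2CCC(c3ccccc3)CC2)ccn(CC2CCC2)c1=O` gives 55 nM in a functional assay on CHO cells for positive allosteric modulation of metabotropic glutamate receptor 2 (Homo sapiens), with a stated time of 30 min; a lower number here means that less compound is needed, a higher number that more compound is needed for the effect.
Compound 2 `N#Cc1c(N2CCC(c3ccccc3)CC2)ccn(CC2CC2)c1=O` gives 151 nM in this assay.

For the measured compounds named here, compound 2 has the higher of the two numbers measured so far; compound 1 is the nearest and lower, and the single measured step, a 2.7-fold higher number from compound 1 to compound 2 (0.44 log units; beyond the scatter), concerns only the cyclopropyl-for-cyclobutyl swap on the chain attached to the aromatic nitrogen.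

Compound 3 `O=c1c(Cl)c(N2CCC(c3ccccc3)CC2)ccn1CC1CC1` is not yet measured. It differs from compound 2 in one place: chloro in place of cyano on an aromatic carbon. Going by the values given here, no measured step touches this part of the shared core, so the only step on record, from compound 1 to compound 2, offers no guide to the size or direction of the change at hand. Without such a precedent, the expectation rests on the fact that a small group replaces another small group on the same aromatic carbon, so a step of modest size in either direction, or none beyond the scatter, seems plausible.

In this assay compound 3 is therefore estimated at 250 nM, within the range 80 nM to 800 nM, which means an expected step of a 1.7-fold higher number from compound 2 to compound 3 (0.22 log units; within the scatter).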

Compound 3, half-maximal effective concentration: 170 nM
Estimate against measurement, compound 3: 1.5-fold (0.17 log units) above, and the stated range covers the measured number.
By their numbers in this assay, from the lowest: compound 1; then compounds 2 and 3 (each within the scatter of the next).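

At this position on the shared core, the first measured change shows that replacing the nitrile with chloro gives a 1.1-fold higher number from compound 2 to compound 3 (0.05 log units; within the scatter) in this assay, so the two compounds cannot be told apart by this measurement. The groups differ in what is counted for them. The cyano group has two heavy atoms, a triple bond and a hydrogen-bond acceptor, whereas chloro is a single chlorine atom with no hydrogen-bond acceptor. With the cyclopropylmethyl group in place, neither the triple bond nor the acceptor is needed to keep the number within the scatter. No measurement shown here gives a reason why the two groups read alike.

On these data alone, what remains open is whether a methyl group, a methoxy group or an amine on this aromatic carbon would also give a number close to those of compound 2 and compound 3. As far as these compounds go, it is also open whether chloro in place of cyano would give the same result alongside the cyclobutyl chain of compound 1, since this one step comes from the cyclopropylmethyl series alone.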